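Fluoro for Amino on the Fused Ring of a Sulfonamide Series

The source may report more compounds than this note shows. Statements on the series, on what has been measured and on what is new or still open speak of the compounds shown alone.

Measured compounds in a functional assay on HCT-116 cells (Homo sapiens) for antiproliferative activity, read by MTT assay, with a stated time of 72 h; on this read-out higher numbers stand for weaker inhibition and lower numbers for stronger inhibition:
compound 1 `O=S(=O)(c1ccc(-c2cnc(C3CC3)o2)cc1)N1CCSc2ccccc21`: 45 nM
compound 2 `Nc1ccc2c(c1)OCCCN2S(=O)(=O)c1ccc(-c2cnc(C3CC3)o2)cc1`: 87 nM
compound 3 `O=S(=O)(c1ccc(-c2cnc(C3CC3)o2)cc1)N1CCCOc2ccc(F)cc21`: 24 nM

Compound 2 stands highest of the three numbers. Its nearest neighbour is compound 1, whose number is lower by an amount within the scatter, so the two cannot be ordered. Compound 3 lies furthest, with a number lower by an amount beyond the scatter.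

Compound 4 `O=S(=O)(c1ccc(-c2cnc(C3CC3)o2)cc1)N1CCCOc2cc(F)ccc21` has not been measured. It differs from compound 2 by fluoro in place of amino on an aromatic carbon.

Among the measured compounds shown here, no step between measured compounds is known for this change. Because compound 3, which also carries a fluoro, gives 24 nM, a step toward a lower number, beyond the scatter, is expected. Compound 4 is expected to give about 35 nM, within 15 nM to 80 nM. This expectation means a step of a 2.5-fold lower number from compound 2 to compound 4 (0.40 log units; beyond the scatter).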

Compound 4, half-maximal inhibitory concentration: 30 nM
For compound 4 the middle estimate is 1.2-fold (0.07 log units) above the measured one; the range from low to high includes it.
By their numbers in this assay, from the lowest: compounds 3, 4, 1 and 2 (each within the scatter of the next, the first and the last beyond it).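

In this assay fluoro in place of amino on an aromatic carbon gives a 2.9-fold lower number from compound 2 to compound 4 (0.46 log units; beyond the scatter) and so shows that the amino group is not required at this position for activity in these cells. The number falls even though the change removes the hydrogen-bond donor and acceptor counted for amino. Nothing available explains this step. On these data alone, whether a hydroxyl, a methoxy group or a chlorine atom on the same carbon would give a similar number remains open, as does the result with only hydrogen there.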